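Adding a second chloro to compound 3

The source may hold more compounds than are shown below. What is called first, only, known or untested is meant among the compounds shown, and "the series" means these compounds.

Read-outs from a functional assay on A549 cells (Homo sapiens) for antiproliferative activity, read by MTT assay, with a stated time of 48 h (a higher number here means a weaker inhibitor, a lower number a stronger inhibitor), so far
compound 1 `Clc1cc2nc(-c3cn(-c4ccccc4)nc3-c3ccccc3)[nH]c2cc1Cl` gives 11100 nM
compound 2 `Fc1ccc(-c2nn(-c3ccccc3)cc2-c2nc3cc(F)ccc3[nH]2)cc1` gives 1130 nM
compound 3 `Fc1ccc(-c2nn(-c3ccccc3)cc2-c2nc3cc(Cl)ccc3[nH]2)cc1` gives 1320 nM

Compound 3 sits level with compound 2 within the scatter, and compound 1 stands clearly higher than both. Compound 4 `Fc1ccc(-c2nn(-c3ccccc3)cc2-c2nc3cc(Cl)c(Cl)cc3[nH]2)cc1` has chloro in place of hydrogen on an aromatic carbon, ortho to a chloro group (chloro in place of hydrogen on an aromatic carbon). Among the measured compounds shown here, the only measured step (a 1.2-fold higher number from compound 2 to compound 3 (0.07 log units; within the scatter)) puts chloro in place of fluoro and adds no halogen, so it bears only loosely on this change. Compound 1, which also carries two chloro groups but no fluoro, gives 11100 nM and points upward. A step to a higher number in this assay is expected (a 2.1-fold higher number from compound 3 to compound 4 (0.33 log units; beyond the scatter)). Compound 4 is estimated at 2800 nM with a range from 900 nM to 9000 nM on this reading.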

Compound 4, half-maximal inhibitory concentration: 15700 nM
Beside the measured number, compound 4's estimate is 5.6-fold (0.75 log units) below it, outside the stated range (above it).
By their numbers in this assay, from the lowest: compounds 2 and 3 (each within the scatter of the next); then compounds 1 and 4 (each within the scatter of the next).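

In this assay, the second chloro, ortho to a chloro group, moves the number far more than the exchange of fluoro for chloro did (a 12-fold higher number from compound 3 to compound 4 (1.08 log units; beyond the scatter)). With both chloro groups present, adding a fluoro group gives only a shift within the scatter (a 1.4-fold higher number from compound 1 to compound 4 (0.15 log units; within the scatter)). Nothing measured here accounts for the large step.

Still open, from the compounds shown here alone, is whether a methoxy group or an amine at this position would give a step of similar size. Also open, going by these compounds, is whether a chloro here needs the neighbouring chloro to produce it.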